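The compounds below may be only part of what the source reports. "The series", "measured", "known", "first", "only" and "open" are said of these compounds alone.

In an ADME assay on L02 cells (Homo sapiens) for cytotoxicity, read by MTT assay, with a stated time of 48 h (a lower number here means a stronger inhibitor, a higher number a weaker inhibitor), compound 3 `CCN(CC)c1ccc2cc(C(=O)c3ccc(N4CCN(C(=O)CN5CCN(S(=O)(=O)c6ccc(C(F)(F)F)cc6)CC5)CC4)cc3)oc2c1` gives 17000 nM, the lower of the two plain numbers found, though compound 1 `CCN(CC)c1ccc2cc(C(=O)c3ccc(N4CCN(C(=O)CN5CCN(C(=O)CCl)CC5)CC4)cc3)oc2c1`, with 20900 nM, sits within the scatter of it. Compound 2 `CCN(CC)c1ccc2cc(C(=O)c3ccc(N4CCN(C(=O)CN5CCN(S(=O)(=O)C6CC6)CC5)CC4)cc3)oc2c1` gives only a limit of the assay, > 100000 nM, namely (the limit of > 100000 nM in this assay, at which 1 of the 3 values shown sits). Compound 4 `CCN(CC)c1ccc2cc(C(=O)c3ccc(N4CCN(C(=O)CN5CCN(S(=O)(=O)c6ccc(C#N)cc6)CC5)CC4)cc3)oc2c1` differs from compound 3 by cyano in place of trifluoromethyl on an aromatic carbon. The measured steps changed the whole group on the amine nitrogen or on the sulfonyl sulfur: an at least 4.7-fold higher number from compound 1 to compound 2 (0.67 log units; beyond the scatter) and an at least 5.8-fold lower number from compound 2 to compound 3 (0.76 log units; beyond the scatter). Neither exchanges one group for another on the 4-(trifluoromethyl)phenyl ring, so they bear only loosely on this change. Compound 4 is therefore expected to give about 20000 nM, between 8000 nM and 60000 nM, an estimated step of a 1.2-fold higher number from compound 3 to compound 4 (0.07 log units; within the scatter) that is not expected to go beyond the scatter.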

Compound 4, half-maximal inhibitory concentration: 44100 nM
The estimate for compound 4 lay 2.2-fold (0.34 log units) below the measured number; the measured number falls inside the stated range.
By their numbers in this assay, from the lowest: compounds 3 and 1 (each within the scatter of the next); then compound 4. At a limit, above all of these: compound 2.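

Cyano in place of trifluoromethyl, para to a large group, gives in this assay a 2.6-fold higher number from compound 3 to compound 4 (0.41 log units; beyond the scatter) and so shows that the group at this ring position matters, while a 2.1-fold higher number from compound 1 to compound 4 (0.32 log units; beyond the scatter) now separates the sulfonyl series from the (chloromethyl)carbonyl compound, which compound 3 did not do. Compound 2 stands at a limit of the assay, so an at least 2.2-fold lower number from compound 2 to compound 4 (0.35 log units; beyond the scatter) is only a bound. No measurement shown gives a reason for these differences. Going by these compounds, whether an amine or a methoxy group at this ring carbon would give a number nearer compound 3 or compound 4 stays open.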